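A few compounds are considered here, and "the series" means these few. Any claim that something is new, unique, unknown or untested is made for them only; others in the source may bear on it.

The shared core is carried here by compound 2, `Nc1nc(NCc2ccccc2)c2ncn(/C=C3/CC3(CO)CO)c2n1`, whose toxicity is judged in an ADME assay on BCBL1 cells (Homo sapiens) for cytotoxicity, with a stated time of 7 days; on this read-out higher numbers stand for lower toxicity in this test and lower numbers for higher toxicity in this test. In this assay compound 2 gives 19900 nM, the only result reported as a number. Compound 1, `C=CCOc1nc(N)nc2c1ncn2/C=C1/CC1(CO)CO`, reaches the limit of this assay with > 20000 nM. Compound 3, `CC(C)Sc1nc(N)nc2c1ncn2/C=C1/CC1(CO)CO`, likewise reaches the limit of this assay with > 20000 nM. The step from compound 1 to compound 2 therefore reads as a number no higher from compound 1 to compound 2 (the limit leaves the size open), and the step from compound 2 to compound 3 as a number no lower from compound 2 to compound 3 (the limit leaves the size open); with the limit of > 20000 nM in this assay, at which 2 of the 3 values shown sit, neither step has a readable size, and nothing among these three compounds separates them beyond the usual scatter.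

Compound 4, `CCCOc1nc(N)nc2c1ncn2/C=C1/CC1(CO)CO`, is still to be measured. It differs from compound 2 by propoxy in place of benzylamino on an aromatic carbon. Compound 1 carries allyloxy at the same place, and compound 1 sits at the limit of this assay. Compound 4 is therefore expected to land at or near the same limit, with an estimated 25000 nM, between 12000 nM and 60000 nM. The expected step from compound 2 to compound 4 is a 1.3-fold higher number from compound 2 to compound 4 (0.10 log units; within the scatter), a move that is expected to stay within the usual scatter.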

Compound 4, half-maximal cytotoxic concentration: > 20000 nM
Compound 4 gave a limit, no number; the forecaster's own chance of this, stated with the estimate: 70%; the middle value is on the limit's open side.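

With propoxy on this aromatic carbon, this assay shows a number no lower from compound 2 to compound 4 (the limit leaves the size open), and compound 4 gives a limit rather than a number. Among these compounds, compound 4 thus adds a saturated oxygen-linked chain to the allyloxy of compound 1 and the isopropylsulfanyl of compound 3 among the groups at this place that end at a limit, while benzylamino in compound 2 remains the only group here with a numerical result. The steps from compound 1 and compound 3 to compound 4 cannot be read, because both ends of each step sit at a limit, so the change from vinyl to ethyl on the chain has no readable size: the limit of > 20000 nM in this assay, at which 3 of the 4 values shown sit.

The compounds shown leave open how far compound 1, compound 3 and compound 4 lie from one another beyond the limit, and whether any real gap separates them from compound 2. They also leave open whether a longer chain, a morpholine or a carboxylic acid at this place would give a number clearly lower in this assay, since none of the four compounds shows a step of readable size.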